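A few compounds are considered here, and "the series" means these few. Any claim that something is new, unique, unknown or untested is made for them only; others in the source may bear on it.

Two compounds of a shared core have been run in an ADME assay on microsomes from liver (Mus musculus) for metabolic stability; on this read-out lower numbers stand for slow clearance and higher numbers for fast clearance. Compound 1, `CCOc1cc([C@](O)(CCN(C)C)[C@@H](c2cc3cc(Br)ccc3nc2OC)c2ccnc(OC)c2OC)cc(OC)n1`, gives 7.6 uL/min in this assay. Compound 2, `COc1cc([C@](O)(CCN(C)C)[C@@H](c2cc3cc(Br)ccc3nc2OC)c2cccc(OC)c2F)cc(OC(F)F)n1`, gives 6.4 uL/min in this assay. These two numbers sit within the usual scatter of each other, so compound 2 cannot be told apart from compound 1 on clearance, and neither can be called the more stable of the pair.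

Compound 3, `COc1cc([C@](O)(CCN(C)C)[C@@H](c2cc3cc(Br)ccc3nc2OC)c2ccnc(OC)c2OC)cc(OC(F)F)n1`, has not yet been run. It differs from compound 2 in one place: 2,3-dimethoxypyridin-4-yl in place of 2-fluoro-3-methoxyphenyl on a saturated chain carbon bound to an aromatic carbon and a saturated chain carbon. The group that enters is the same group that compound 1 already carries on that chain carbon, and compound 1 is cleared no faster than compound 2 within the scatter. For the measured compounds named here, no step between measured compounds is available to say how this exchange alone moves clearance, so the expected step from compound 2 to compound 3 in this assay is a 1.1-fold higher number from compound 2 to compound 3 (0.04 log units; within the scatter), none beyond the scatter. Compound 3 is therefore estimated at 7 uL/min, within a range of 3.5 uL/min to 14 uL/min, because compound 1 gives 7.6 uL/min while carrying the same entering group.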

Compound 3, intrinsic clearance in a liver preparation (reported as CLH), per the amount of preparation that the assay uses: 4.9 uL/min
Estimate against measurement, compound 3: 1.4-fold (0.15 log units) above; low and high end bracket the measured number.
By their numbers in this assay, from the lowest: compounds 3, 2 and 1 (each within the scatter of the next).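

In this assay, 2,3-dimethoxypyridin-4-yl in place of 2-fluoro-3-methoxyphenyl on the saturated chain carbon gives a 1.3-fold lower number from compound 2 to compound 3 (0.12 log units; within the scatter) and stays within the usual scatter, so on clearance these two groups cannot be told apart at this position, even though the entering group brings a hetero atom into the ring and more hydrogen-bond acceptors. The new compound also links to compound 1 through a second place: difluoromethyl in place of ethyl on an oxygen on an aromatic ring gives a 1.6-fold lower number from compound 1 to compound 3 (0.19 log units; within the scatter) and also stays within the scatter, so neither exchange separates the compounds on this read-out. Nothing shown here speaks to why the numbers lie where they do.

On these data alone, each exchange is read only once, on a single partner compound, so it remains open whether either would give the same result on another background. As far as these compounds go, it is also open whether a ring carrying an amine or a carboxylic acid on the saturated chain carbon, or a longer chain such as butyl on the oxygen, would give a step beyond the scatter.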